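Amide variation at the carboxyl of the core

This account rests on a few compounds, and the source may have more. Where it says the series, first, only, none or still open, it means among the compounds named here.

Compound 3 `CCCCCN(CCCCC)C(=O)N1CCN(C(=O)N(c2ccccc2)c2ccccc2)[C@H](C(=O)NCCCN(CC)CC)C1` carries the shared core with a (3-(diethylamino)propyl)amino group on the carbonyl carbon. Among the measured compounds shown here, in an assay on CHO cells for binding affinity to Substance-P receptor (Homo sapiens) (on this read-out higher numbers stand for weaker inhibition and lower numbers for stronger inhibition), compound 3 gives 41 nM, the lowest of the three numbers so far. The parent acid, compound 1 `CCCCCN(CCCCC)C(=O)N1CCN(C(=O)N(c2ccccc2)c2ccccc2)[C@H](C(=O)O)C1`, gives 130 nM in this assay, and the step of a 3.2-fold lower number from compound 1 to compound 3 (0.50 log units; beyond the scatter) is modest but beyond the scatter. Compound 2 `CCCCCN(CCCCC)C(=O)N1CCN(C(=O)N(c2ccccc2)c2ccccc2)[C@H](C(=O)NCCN(C(C)C)C(C)C)C1`, with a (2-(diisopropylamino)ethyl)amino group, gives 217 nM in this assay; the step of a 1.7-fold higher number from compound 1 to compound 2 (0.22 log units; within the scatter) lies within the scatter, while a 5.3-fold lower number from compound 2 to compound 3 (0.72 log units; beyond the scatter) is modest and beyond it.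

Compound 4 `CCCCCN(CCCCC)C(=O)N1CCN(C(=O)N(c2ccccc2)c2ccccc2)[C@H](C(=O)N(C)CCN(C)C)C1` differs from compound 3 by (2-(dimethylamino)ethyl)(methyl)amino in place of (3-(diethylamino)propyl)amino on a carbonyl carbon. The group entering is smaller than the group leaving and lacks the hydrogen-bond donor. For the measured compounds named here, the steps that bear on this are the two amide steps from compound 1 and the comparison of the two amides themselves: a shorter chain with a bulkier amine (compound 2) sat near the acid, the longer chain with the smaller amine (compound 3) gave the lowest number. Compound 4 combines a short chain with a small amine, so a number between those of compound 3 and compound 1 is expected, a step of a 2.2-fold higher number from compound 3 to compound 4 (0.34 log units; beyond the scatter) in this assay. Compound 4 is estimated at 90 nM, within 35 nM to 250 nM.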

Compound 4, half-maximal inhibitory concentration: 930 nM
For compound 4 the middle estimate is 10-fold (1.01 log units) below the measured one; the measured number lies above the stated range.
By their numbers in this assay, from the lowest: compound 3; then compounds 1 and 2 (each within the scatter of the next); then compound 4.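

Notes on the carbonyl position: replacing the (3-(diethylamino)propyl)amino group with (2-(dimethylamino)ethyl)(methyl)amino gives a 23-fold higher number from compound 3 to compound 4 (1.36 log units; beyond the scatter), a large step in this assay and the largest seen at this carbonyl carbon so far. The same group also gives a 4.3-fold higher number from compound 2 to compound 4 (0.63 log units; beyond the scatter) and a 7.2-fold higher number from compound 1 to compound 4 (0.85 log units; beyond the scatter), both modest, so compound 4 has the highest number of the four and an amide here can rank clearly behind the parent acid, which neither compound 2 nor compound 3 showed. Among the amides shown, the change to the tertiary amide without the amide hydrogen goes with the highest number, but chain and amine differ at the same time, and no supporting measurement bears on the reason for these steps.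

The compounds shown leave open how much of the step belongs to the methyl on the amide nitrogen, how much to the shorter chain and how much to the dimethylamino group. The (2-(dimethylamino)ethyl)amino amide, which keeps the amide hydrogen, and the (3-(diethylamino)propyl)(methyl)amino amide, which loses it while keeping the longer chain, would each separate one of these changes from the others.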